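A few compounds are considered here, and "the series" means these few. Any claim that something is new, unique, unknown or untested is made for them only; others in the source may bear on it.

Compound 1 `COc1ncnc2c1c(-c1ccsc1)cn2[C@@H]1O[C@H](CO)[C@@H](O)[C@H]1O`: in a functional assay on HepG2 cells (Homo sapiens) for antiproliferative activity, read by XTT assay, with a stated time of 72 h (a lower number here means a stronger inhibitor, a higher number a weaker inhibitor), compound 1 gives 430 nM.
Compound 2 `COc1nc(N)nc2c1c(-c1ccsc1)cn2[C@@H]1O[C@H](CO)[C@@H](O)[C@H]1O`: in this assay compound 2 reaches only a limit of the measurement, > 20000 nM.
Compound 3 `O=c1[nH]cnc2c1c(-c1ccco1)cn2[C@@H]1O[C@H](CO)[C@@H](O)[C@H]1O`: in this assay compound 3 likewise reaches only a limit of the measurement, > 15000 nM.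

Compound 1 and compound 2 share a core and differ in one place: amino in place of hydrogen on an aromatic carbon. That change brings an at least 46-fold higher number from compound 1 to compound 2 (1.66 log units; beyond the scatter), so the measured number moves from a clear value to a limit, as shown by the limit of > 20000 nM in this assay, at which 1 of the 3 values shown sits.

Compound 3 carries a different core, and the difference between the two cores is not broken down here. For compound 3 the measurement ends at a limit, (the limit of > 15000 nM in this assay, at which 1 of the 3 values shown sits).

Compound 4 `Nc1nc2c(c(-c3ccco3)cn2[C@@H]2O[C@H](CO)[C@@H](O)[C@H]2O)c(=O)[nH]1` has not yet been measured. It differs from compound 3 by amino in place of hydrogen on an aromatic carbon. Within the data shown here, this is the same kind of change as the one from compound 1 to compound 2, not the same: around the place, the new amino group in compound 4 sits meta to a group of 1 heavy atom, whereas in compound 2 it sits meta to a methoxy group (2 heavy atoms).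

Since compound 3 already sits at a limit, and since the earlier step of an at least 46-fold higher number from compound 1 to compound 2 (1.66 log units; beyond the scatter) made the number larger, compound 4 is expected to give a number that is again only a limit, with a step that the limit leaves unreadable from compound 3 to compound 4. The estimate for compound 4 in this assay is 40000 nM, expected to lie between 15000 nM and 150000 nM.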

Compound 4, half-maximal inhibitory concentration: > 20000 nM
Compound 4 was reported as a limit; the forecaster's own chance of this, stated with the estimate: 90%; the middle value is on the limit's open side.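

In this assay compound 3 gives > 15000 nM as a limit of the measurement. Compound 4 gives > 20000 nM as a limit too, so the step between these two compounds cannot be read. The compounds shown leave open whether amino in place of hydrogen on the core of compound 3 moves the number in this assay at all, and if so, by how much.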